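This account rests on a few compounds, and the source may have more. Where it says the series, first, only, none or still open, it means among the compounds named here.

Measured so far:
Compound 1, `O=C(c1cc(Oc2ccc(/C=C/c3ccccn3)cc2)ccn1)N1CCCC1`: in a functional assay on HepG2 cells (Homo sapiens) for antiproliferative activity, read by CCK-8 assay, with a stated time of 48 h (a higher number here means a weaker inhibitor, a lower number a stronger inhibitor), compound 1 gives 27000 nM.
Compound 2, `COc1ccc(CNC(=O)c2cc(Oc3ccc(/C=C/c4ccncc4)cc3)ccn2)cc1`: in this assay compound 2 reaches only a limit, > 100000 nM.
Compound 3, `O=C(NC1CC1)c1cc(Oc2ccc(/C=C/c3ccncc3)cc2)ccn1`: in this assay compound 3 gives 77500 nM.

Among the two numbers measured, compound 3 holds the highest; compound 1 is its nearest neighbour with a lower number, a gap beyond the scatter, and the value of compound 2 is a limit rather than a number. Going by the values given here, the one step that can be counted is an at least 1.2-fold lower number from compound 2 to compound 3 (0.11 log units; that floor lies within the scatter); it has only a floor because compound 2 sits at the limit of > 100000 nM in this assay, at which 1 of the 3 values shown sits. That step changes the group on the amide-type nitrogen, as does the step now at hand.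

Compound 4, `O=C(c1cc(Oc2ccc(/C=C/c3ccncc3)cc2)ccn1)N1CCCC1`, differs from compound 3 by pyrrolidin-1-yl in place of cyclopropylamino on a carbonyl carbon. Compound 1 also carries pyrrolidin-1-yl on the carbonyl, but differs from compound 4 elsewhere as well, so its value can only be set beside that of compound 3. From the floor of the measured step and the lower number of compound 1, a moderate drop is expected for compound 4, a 1.9-fold lower number from compound 3 to compound 4 (0.29 log units; within the scatter). Compound 4 is therefore estimated at 40000 nM, within 15000 nM to 100000 nM.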

Compound 4, half-maximal inhibitory concentration: 41600 nM
The estimate for compound 4 lay 1.0-fold (0.02 log units) below the measured number, within the range that was stated.
By their numbers in this assay, from the lowest: compounds 1, 4 and 3 (each within the scatter of the next, the first and the last beyond it). At a limit, above all of these: compound 2.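

In this assay, the step that removes the amide hydrogen by setting pyrrolidin-1-yl in place of cyclopropylamino on the carbonyl carbon is a 1.9-fold lower number from compound 3 to compound 4 (0.27 log units; within the scatter), so this change cannot be told from the scatter, and the same holds for pyridin-4-yl in place of pyridin-2-yl, a 1.5-fold higher number from compound 1 to compound 4 (0.19 log units; within the scatter). Pyrrolidin-1-yl in place of (4-methoxybenzyl)amino gives an at least 2.4-fold lower number from compound 2 to compound 4 (0.38 log units; beyond the scatter), the first step at this carbonyl carbon that lies beyond the scatter, though it is only a floor. Compound 2 gives a limit and not a number: the limit of > 100000 nM in this assay, at which 1 of the 4 values shown sits.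

On these data alone, whether a morpholin-4-yl or piperidin-1-yl group on this carbonyl carbon would give a step beyond the scatter remains open. A carboxylic acid in place of the amide also remains untested among the compounds shown.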